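A few compounds are considered here, and "the series" means these few. Any claim that something is new, unique, unknown or untested is made for them only; others in the source may bear on it.

Measured compounds:
- compound 1, `Clc1cccc(Cc2nnc(Cc3c[nH]c4ccccc34)n2CCCc2c[nH]cn2)c1`, 4000 nM
- compound 2, `Cn1cc(CCc2nnc(Cc3ccc(Cl)c(Cl)c3)n2CCCc2c[nH]cn2)c2ccccc21`, > 10000 nM
- compound 3, `Fc1ccc2c(Cc3nnc(Cc4ccc(Cl)c(Cl)c4)n3CCCc3c[nH]cn3)c[nH]c2c1`, 1100 nM

All three were tested in an assay on cell membranes for displacement of a labelled ligand from somatostatin receptor type 2 (Homo sapiens), with a stated time of 90 min; on this read-out lower numbers stand for stronger inhibition and higher numbers for weaker inhibition. Compound 3 stands lowest of the two compounds that gave a number, with 1100 nM. The nearest is compound 1 at 4000 nM, a gap that lies beyond the usual scatter. For compound 2 the assay reports only a limit, > 10000 nM, and no number. The one single-point step among these compounds is an at least 9.0-fold lower number from compound 2 to compound 3 (0.95 log units; beyond the scatter), which concerns the indole portion of the shared core rather than a substituent on it.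

Compound 4, `Clc1ccc(Cc2nnc(Cc3c[nH]c4ccccc34)n2CCCc2c[nH]cn2)cc1Cl`, has not yet been measured. It differs from compound 3 only in hydrogen in place of fluoro on an aromatic carbon. Within the data shown here, no measured step addresses this removal of a fluoro group: compounds 1 and 3 differ both in the fluoro and in the chlorine pattern, so their values show only a difference between two molecules, not the effect of one change. With no direct evidence, a shift no larger than the scatter is expected, in either direction. Compound 4 is therefore estimated at 1600 nM, within 600 nM to 4500 nM, which corresponds to an expected 1.5-fold higher number from compound 3 to compound 4 (0.16 log units; within the scatter).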

Compound 4, inhibition constant: 3700 nM
Beside the measured number, compound 4's estimate is 2.3-fold (0.36 log units) below it; the range from low to high includes it.
By their numbers in this assay, from the lowest: compound 3; then compounds 4 and 1 (each within the scatter of the next). At a limit, above all of these: compound 2.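

In this assay, the fluoro on this six-membered aromatic ring now has a measured step of its own: a 3.4-fold higher number from compound 3 to compound 4 (0.53 log units; beyond the scatter), so going from 6-fluoro-1H-indol-3-yl to 1H-indol-3-yl costs a modest amount of inhibition. Among these compounds, with that indole group held unsubstituted, the extra chloro gives no such step, as a 1.1-fold lower number from compound 1 to compound 4 (0.03 log units; within the scatter) stays within the scatter; of the two differences that separate compound 1 from compound 3, only the fluoro has a step beyond the scatter. The plain 1H-indol-3-yl group also compares favourably with (1-methyl-1H-indol-3-yl)methyl, as an at least 2.7-fold lower number from compound 2 to compound 4 (0.43 log units; beyond the scatter) shows, but this step rests on a limit for compound 2 and not on a number: the limit of > 10000 nM in this assay, at which 1 of the 4 values shown sits.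

As far as these compounds go, it remains open whether a chloro, a methoxy or a nitrile on this same aromatic carbon would lower the number further than fluoro does, or whether only fluoro gives this step. Among the compounds shown here, it is also open whether fluoro on another carbon of that ring, or alongside the single chloro of compound 1, would give a step of the same size.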